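Trifluoromethyl in Place of Methyl: Expectation for Compound 3

This account rests on a few compounds, and the source may have more. Where it says the series, first, only, none or still open, it means among the compounds named here.

Of the compounds shown here, two have been measured in a functional assay on Hep 3B2 cells (Homo sapiens) for antiproliferative activity, read by MTT assay, with a stated time of 24 h, tested at 3.7 ug/mL; on this read-out lower numbers stand for a weaker effect and higher numbers for a stronger effect at the one concentration tested. Compound 1 `Cc1ccc2nc(C(=O)Nc3c(F)cc(-c4cccc(F)c4)cc3F)c(C)c(O)c2c1` gives 19.2% in this assay. Within the data shown here, compound 2 `Cc1ccc2nc(C(=O)Nc3c(F)cc(-c4cccc(F)c4)cc3F)c(C)c(C(=O)O)c2c1` gives 31.3% in this assay, the higher of the two numbers, and the only measured step, a number 12.1 percentage points higher from compound 1 to compound 2 (beyond the scatter), separates them. Compound 3 `Cc1c(C(=O)Nc2c(F)cc(-c3cccc(F)c3)cc2F)nc2ccc(C(F)(F)F)cc2c1C(=O)O` is the compound still to be measured.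

trifluoromethyl in place of methyl on an aromatic carbon

Among the measured compounds shown here, no measured step touches this part of the shared core: the one step known changes a different group, so it gives no guide to the size or direction of a change at this place. Without such a guide, compound 3 is expected to sit close to compound 2, with no step beyond the scatter. The step expected in this assay is a number 0.3 percentage points lower from compound 2 to compound 3 (within the scatter). Compound 3 is therefore estimated at 31%, within a range from 15% to 50%.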

Compound 3, a percentage reported as inhibition, at one concentration (the size of the read-out at that concentration, not a potency): 21.3%
Estimate against measurement, compound 3: 9.7 percentage points above; measured number inside the range.
By their numbers in this assay, from the lowest: compounds 1, 3 and 2 (each within the scatter of the next, the first and the last beyond it).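

Among these compounds, this is the first measured change at this place on the shared core, and in this assay it gives a number 10 percentage points lower from compound 2 to compound 3 (within the scatter). Trifluoromethyl in place of methyl on this aromatic carbon therefore does not produce a difference that this read-out can separate from the usual scatter, so the two compounds cannot be ranked and the position cannot be called sensitive or insensitive to this change. Nothing measured here bears on what lies behind this result.

As far as these compounds go, whether another group on this aromatic carbon, such as an amine or a methoxy group, would give a step beyond the scatter remains open. Also open, from the compounds shown here alone, is whether the same swap would give a similar step on the core of compound 1, which carries hydroxy in place of carboxy.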